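Amide aryl swap and kinetic solubility at neutral pH

This account rests on a few compounds, and the source may have more. Where it says the series, first, only, none or still open, it means among the compounds named here.

Of the compounds shown here, three on one shared core have been measured in a physicochemical assay for solubility, in phosphate buffer, measured as kinetic solubility, with a stated time of 1 h, at pH 7.4; on this read-out higher numbers stand for higher solubility and lower numbers for lower solubility. Compound 1 `COc1ccc2nc(C)cc(OCC(=O)NCc3cc(C)cc(C)c3)c2c1` gives 92000 nM. Compound 2 `COc1ccc2nc(C)cc(OCC(=O)Nc3cccc(C)c3)c2c1` gives 193000 nM. Compound 3 `COc1ccc2nc(C)cc(OCC(=O)Nc3cc(F)cc(F)c3)c2c1` gives 13000 nM, the lowest of the three numbers. The measured steps are a 2.1-fold higher number from compound 1 to compound 2 (0.32 log units; beyond the scatter), a 7.1-fold lower number from compound 1 to compound 3 (0.85 log units; beyond the scatter) and a 15-fold lower number from compound 2 to compound 3 (1.17 log units; beyond the scatter). Compound 4 `COc1ccc2nc(C)cc(OCC(=O)Nc3cccnc3)c2c1` differs from compound 3 by pyridin-3-yl in place of 3,5-difluorophenyl on an amide-type nitrogen. The steps of a 15-fold lower number from compound 2 to compound 3 (1.17 log units; beyond the scatter) and a 7.1-fold lower number from compound 1 to compound 3 (0.85 log units; beyond the scatter) both show how far this assay falls when 3,5-difluorophenyl enters on the amide-type nitrogen; taking it out again for pyridin-3-yl is therefore expected to raise the number by a large step, a 19-fold higher number from compound 3 to compound 4 (1.28 log units; beyond the scatter). Compound 4 is estimated at 250000 nM, within a range of 80000 nM to 800000 nM.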

Compound 4, solubility: 32000 nM
Beside the measured number, compound 4's estimate is 7.8-fold (0.89 log units) above it; measured number outside the range, below it.
By their numbers in this assay, from the lowest: compound 3; then compound 4; then compound 1; then compound 2.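

In this assay pyridin-3-yl on the amide-type nitrogen gives back only part of the fall seen with 3,5-difluorophenyl, with a 2.5-fold higher number from compound 3 to compound 4 (0.39 log units; beyond the scatter) but also a 6.0-fold lower number from compound 2 to compound 4 (0.78 log units; beyond the scatter) and a 2.9-fold lower number from compound 1 to compound 4 (0.46 log units; beyond the scatter) at this position. Removing 3,5-difluorophenyl is thus not enough to reach the higher numbers, and a ring with a hetero atom still ranks below the 3-methylphenyl and 3,5-dimethylbenzyl groups. Nothing given here explains this order. From the compounds shown here alone, whether a morpholine or a carboxylic acid on the aryl ring would carry the number past that of compound 2 stays open.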